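Capping the Phenol of Compound 2: Expected Tolerance

The source may report more compounds than this note shows. Statements on the series, on what has been measured and on what is new or still open speak of the compounds shown alone.

Compound 1 `COCOc1ccc(CN(Cc2ccc(C(C)(C)C)cc2)Cc2cc3cc(C)ccc3[nH]c2=O)cc1` gives 6400 nM in a toxicity assay on MDCK cells (Canis lupus familiaris) for cytotoxicity, read by crystal violet staining, with a stated time of 48 h; a lower number here means that less compound is tolerated, a higher number that more compound is tolerated.
Compound 2 `Cc1ccc2[nH]c(=O)c(CN(Cc3ccc(O)cc3)Cc3ccc(C(C)(C)C)cc3)cc2c1` gives 4900 nM in this assay.
Compound 3 `CCc1ccc2[nH]c(=O)c(CN(Cc3ccc(O)cc3)Cc3ccc(C(C)(C)C)cc3)cc2c1` reaches in this assay a limit rather than a number, > 10000 nM.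

Among the two plain numbers, compound 2 has the lower one; its nearest neighbour is compound 1, and the step of a 1.3-fold lower number from compound 1 to compound 2 (0.12 log units; within the scatter) lies within the scatter, so the two cannot be ranked. Compound 3 sits at the floor described by the limit of > 10000 nM in this assay, at which 1 of the 3 values shown sits.

Compound 4 `COc1ccc(CN(Cc2ccc(C(C)(C)C)cc2)Cc2cc3cc(C)ccc3[nH]c2=O)cc1` differs from compound 2 by methyl in place of hydrogen on an oxygen on an aromatic ring. Going by the values given here, two measured steps bear on this. The step of a 1.3-fold lower number from compound 1 to compound 2 (0.12 log units; within the scatter) removed a methoxymethyl cap from the same oxygen and changed the number by less than the scatter. The step of an at least 2.0-fold higher number from compound 2 to compound 3 (0.30 log units; that floor lies within the scatter) touches a different place, the saturated chain carbon bound to an aromatic carbon, and its floor also lies within the scatter. Neither step points to a change beyond the scatter, so the expected step in this assay from compound 2 to compound 4 is small, a 1.2-fold higher number from compound 2 to compound 4 (0.09 log units; within the scatter), with a slight lean toward more compound being tolerated. Compound 4 is therefore estimated at 6000 nM, with a range from 3000 nM to 12000 nM.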

Compound 4, half-maximal cytotoxic concentration: > 10000 nM
Compound 4 ended at the assay's limit; the forecaster's own chance of this, stated with the estimate: 20%; at least 1.6-fold (0.22 log units) between middle value and limit.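

On the oxygen of the 4-hydroxyphenyl group, methyl in place of hydrogen gives in this assay an at least 2.0-fold higher number from compound 2 to compound 4 (0.30 log units; that floor lies within the scatter), so this change has only a floor for its size, and that floor does not leave the scatter. Compound 1 carries a methoxymethyl cap on the same oxygen and could not be ranked against compound 2, while the swap to methoxy gives an at least 1.5-fold higher number from compound 1 to compound 4 (0.19 log units; that floor lies within the scatter), again a floor within the scatter, so the two caps are not shown to behave alike, though neither step proves a real difference. Compound 4 gives a limit rather than a number, and it is the second compound to stop there: the limit of > 10000 nM in this assay, at which 2 of the 4 values shown sit.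

Going by these compounds, how much compound 4 is tolerated past that limit stays unknown, and so does the true size of both steps that end at it. Also open, on these data alone, is whether an ethoxy group, a longer chain on the same oxygen, or an amine in place of the hydroxy would give a plain number in this assay or stop at the limit as well.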